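Dropping One Methoxy Group: What to Expect

The source may report more compounds than this note shows. Statements on the series, on what has been measured and on what is new or still open speak of the compounds shown alone.

Compound 1 `COc1cc(-c2cc(/C=C/C(=O)c3ccc(N)cc3)[nH]n2)cc(OC)c1OC` — in a functional assay on KM12 cells (Homo sapiens) for inhibition, read by sulforhodamine B assay, with a stated time of 48 h (on this read-out higher numbers stand for weaker inhibition of growth and lower numbers for stronger inhibition of growth), compound 1 gives 2880 nM.
Compound 2 `COc1ccc(C(=O)/C=C/c2cc(-c3cc(OC)c(OC)c(OC)c3)n[nH]2)cc1OC` — in this assay compound 2 gives 2410 nM.

Among the measured compounds shown here, with only two numbers, compound 2 stands within the scatter of compound 1: the step of a 1.2-fold lower number from compound 1 to compound 2 (0.08 log units; within the scatter) reshaped the aryl group on the carbonyl carbon without moving the read-out. Compound 3 `COc1ccc(C(=O)/C=C/c2cc(-c3cc(OC)c(OC)c(OC)c3)n[nH]2)cc1` differs from compound 2 by hydrogen in place of methoxy on an aromatic carbon; the carbon sits ortho to a methoxy group and meta to a large group. For the measured compounds named here, that single measured step is the only guide, and it suggests changes on this aryl group leave the read-out roughly where it is. The step of a 1.1-fold higher number from compound 2 to compound 3 (0.03 log units; within the scatter) is therefore expected to stay within the scatter. Compound 3 is estimated at 2600 nM, with a range from 900 nM to 7500 nM.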

Compound 3, concentration for total growth inhibition: 3060 nM
The estimate for compound 3 lay 1.2-fold (0.07 log units) below the measured number, and the stated range covers the measured number.
By their numbers in this assay, from the lowest: compounds 2, 1 and 3 (each within the scatter of the next).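

Removing one methoxy group, which turns 3,4-dimethoxyphenyl into 4-methoxyphenyl, gives a 1.3-fold higher number from compound 2 to compound 3 (0.10 log units; within the scatter) in this assay, so growth inhibition does not depend measurably on that group. Methoxy and amino on this aryl group also read alike, with a 1.1-fold higher number from compound 1 to compound 3 (0.03 log units; within the scatter). All three aryl groups now sit within the scatter of one another, and nothing measured here bears on the reason. Going by these compounds, whether a carboxylic acid or a dimethylamino group on this aryl group would also leave the read-out in place remains open. So does the effect of any change to the shared core.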